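The source may hold more compounds than are shown below. What is called first, only, known or untested is meant among the compounds shown, and "the series" means these compounds.

Compound 1 `CN(C)c1ccc(C=C2C(=O)N(c3ccc(Cl)cc3)N(c3ccc(Cl)cc3)C2=O)cc1`: > 128000 nM, a limit of the assay and not a number.
Compound 2 `O=C1C(=Cc2ccc(Cl)cc2)C(=O)N(c2ccc(Cl)cc2)N1c1ccc(Cl)cc1`: 30900 nM.
Compound 3 `O=C1C(=Cc2ccc(Br)cc2)C(=O)N(c2ccc(Cl)cc2)N1c1ccc(Cl)cc1`: 16600 nM.

In a functional assay on SMMC-7721 cells (Homo sapiens) for cytotoxicity, read by MTT assay, with a stated time of 72 h (on this read-out lower numbers stand for stronger inhibition and higher numbers for weaker inhibition), the step of a 1.9-fold lower number from compound 2 to compound 3 (0.27 log units; within the scatter) lies within the scatter, so compound 3 stands level with compound 2. The step of an at least 7.7-fold lower number from compound 1 to compound 3 (0.88 log units; beyond the scatter) sets it clearly apart from compound 1. Compound 4 `COc1cc(C=C2C(=O)N(c3ccc(Cl)cc3)N(c3ccc(Cl)cc3)C2=O)ccc1O` carries 4-hydroxy-3-methoxyphenyl in place of 4-bromophenyl on a double-bonded chain carbon bound to a double-bonded ring carbon. Among the compounds with values here, no measured step tests this group directly. The nearest evidence is an at least 4.1-fold lower number from compound 1 to compound 2 (0.61 log units; beyond the scatter) and an at least 7.7-fold lower number from compound 1 to compound 3 (0.88 log units; beyond the scatter), where leaving dimethylamino for either halogen lowered the number. Read in reverse, these suggest that losing bromo may raise it, so a modest rise is expected, a 2.1-fold higher number from compound 3 to compound 4 (0.32 log units; beyond the scatter). The estimated value for compound 4 is 35000 nM, with an expected range from 10000 nM to 120000 nM.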

Compound 4, half-maximal inhibitory concentration: 64900 nM
The estimate for compound 4 lay 1.9-fold (0.27 log units) below the measured number; measured number inside the range.
By their numbers in this assay, from the lowest: compounds 3 and 2 (each within the scatter of the next); then compound 4. At a limit, above all of these: compound 1.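

In this assay, replacing either halogen-bearing phenyl with 4-hydroxy-3-methoxyphenyl on the double-bonded chain carbon raises the number: a 3.9-fold higher number from compound 3 to compound 4 (0.59 log units; beyond the scatter), and a 2.1-fold higher number from compound 2 to compound 4 (0.32 log units; beyond the scatter). Within the data shown here, the position therefore distinguishes this oxygen-bearing ring from both halogenated rings, a contrast the earlier compounds did not test. Replacing 4-(dimethylamino)phenyl with 4-hydroxy-3-methoxyphenyl at the same place gives an at least 1.9-fold lower number from compound 1 to compound 4 (0.29 log units; that floor lies within the scatter). This step cannot be read as a difference, since the value of compound 1 is a limit of the assay: the limit of > 128000 nM in this assay, at which 1 of the 4 values shown sits.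

The compounds shown do not separate the hydroxy group from the methoxy group, as neither appears alone. On these data alone, how a carboxylic acid or a primary amine on this ring would compare also remains open.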